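Swapping chloro for carbamoyl on the shared coumarin-type core

This account rests on a few compounds, and the source may have more. Where it says the series, first, only, none or still open, it means among the compounds named here.

Measured so far:
Compound 1 `CCCOc1cc(=O)oc2cc(OCc3ccccc3)ccc12`: 575 nM
Compound 2 `CCOc1cc(=O)oc2cc(OCc3cccc(F)c3)ccc12`: 263 nM
Compound 3 `O=c1cc(Cl)c2ccc(OCc3cccc(Cl)c3)cc2o1`: 20.9 nM

Of the compounds shown here, three share a core and have been tested in an assay on isolated protein (strain Sprague-Dawley) for inhibition of Amine oxidase [flavin-containing] B (Rattus norvegicus), read by spectrophotometry, with a stated time of 5 min; on this read-out lower numbers stand for stronger inhibition and higher numbers for weaker inhibition. Compound 3 gives the lowest number of the three, and its gaps to compound 2 and to compound 1 both lie beyond the scatter, so compound 3 is the most potent of the set.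

Compound 4 `NC(=O)c1cc(=O)oc2cc(OCc3cccc(Cl)c3)ccc12` is not yet measured. It differs from compound 3 in one place: carbamoyl in place of chloro on an aromatic carbon. Compound 1 and compound 2 carry alkoxy groups at that same place and give far higher numbers than compound 3, which suggests that this position is sensitive to what sits there. Among the measured compounds shown here, with no measured pair showing this exact swap, the expectation is that the carbamoyl group weakens inhibition, giving a higher number than compound 3 by a step beyond the scatter. Compound 4 is therefore estimated at 200 nM, within a range of 40 nM to 1000 nM, which corresponds to an expected step of a 9.6-fold higher number from compound 3 to compound 4 (0.98 log units; beyond the scatter).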

Compound 4, half-maximal inhibitory concentration: 234 nM
The estimate for compound 4 lay 1.2-fold (0.07 log units) below the measured number; the range from low to high includes it.
By their numbers in this assay, from the lowest: compound 3; then compounds 4 and 2 (each within the scatter of the next); then compound 1.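

In this assay, among the compounds shown here, carbamoyl in place of chloro gives an 11-fold higher number from compound 3 to compound 4 (1.05 log units; beyond the scatter), and this is the only pair here that differs in one place. The earlier compounds shown here each differ from one another in more than one place, so they could only hint at what this position does, whereas this step ties a large change in the number to this single swap. Of these two groups on an otherwise identical molecule, chloro gives the lower number, but no measurement here explains the difference.

For the compounds shown here, with only two groups compared at this position, it remains open whether the higher number reflects losing chloro or adding carbamoyl. Placing hydrogen, methyl, a nitrile or a carboxylic acid there, with the rest of compound 3 unchanged, would show how far either group alone sets the number.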